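The source may report more compounds than this note shows. Statements on the series, on what has been measured and on what is new or still open speak of the compounds shown alone.

Working notes on the series in an assay on Cerebral cortex for displacement of a labelled ligand from Adrenergic receptor alpha-1 (Homo sapiens); on this read-out lower numbers stand for stronger inhibition and higher numbers for weaker inhibition.

Compound 1 `Brc1c(Nc2ncc[nH]2)ccc2nccnc12` is recorded only as a limit of the assay: in this assay compound 1 gives > 100000 nM. Compound 2 `c1c[nH]c(Nc2ccc3nccnc3c2)n1` likewise is recorded only as a limit, and in this assay compound 2 gives > 100000 nM. The step between them, a step that the two limits leave unreadable from compound 1 to compound 2, cannot be read as a size, since both ends sit at the limit of > 100000 nM in this assay, at which 2 of the 3 values shown sit. Among the compounds with values here, compound 3 `COc1ccc(Nc2ncc[nH]2)c(C)c1` is the one member of the set with a real number: in this assay compound 3 gives 8400 nM. The values of compound 1 and compound 2 are limits of the assay, so compound 3 stands alone as the single readable point.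

Compound 4 `COc1ccc(Nc2ncc[nH]2)c(C)c1OC` differs from compound 3 by methoxy in place of hydrogen on an aromatic carbon. Within the data shown here, no measured step in the set concerns the entry of a methoxy group; the only step recorded, from compound 1 to compound 2, is unreadable and involves a different change on a different core. Among the measured compounds shown here, there is therefore no measured precedent from which to size the step to compound 4, and the expectation rests on the value of compound 3 alone. The step from compound 3 to compound 4 is expected to be a 1.1-fold lower number from compound 3 to compound 4 (0.02 log units; within the scatter), that is, nothing clearly beyond the scatter in either direction. Compound 4 is accordingly estimated at 8000 nM in this assay, with a range from 2000 nM to 35000 nM.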

Compound 4, inhibition constant: 6600 nM
Compound 4: middle estimate off by 1.2-fold (0.08 log units), on the high side, within the range that was stated.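

In this assay the entry of methoxy on the aromatic carbon ortho to a methoxy group and ortho to a methyl group gives the first step of the series that can be read, a 1.3-fold lower number from compound 3 to compound 4 (0.10 log units; within the scatter), while the only other step cannot be read, since both of its ends are limits: the limit of > 100000 nM in this assay, at which 2 of the 4 values shown sit.

This position therefore takes a methoxy group, with its 2 heavy atoms, without a change that can be told from the scatter. The earlier compounds shown here could not show this, as only one of them carried a number, and the reading still rests on this single pair and this single group.

From the compounds shown here alone, whether the same flat response holds for other groups at this position stays open: an amine, a carboxylic acid or a longer chain on the same aromatic carbon would test it, and one methoxy group cannot tell a position indifferent to substitution from a chance result. Also open, going by these compounds, is whether bromo in place of hydrogen would give a readable step on the core of compound 3, and whether the methoxy and methyl groups already on that core contribute to its value at all.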